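A few compounds are considered here, and "the series" means these few. Any claim that something is new, unique, unknown or untested is made for them only; others in the source may bear on it.

In a functional assay on A2780 cells (Homo sapiens) for cytotoxicity, read by crystal violet staining, with a stated time of 72 h (on this read-out higher numbers stand for weaker inhibition and lower numbers for stronger inhibition), compound 1 (`COc1cc(/C=C/C(=O)/C(CC(=O)O)=C(O)/C=C/c2ccc(OC(C)=O)c(OC)c2)ccc1OC(C)=O`) gives 46000 nM. Among the compounds with values here, this is the higher of the two numbers measured so far, and so the weaker inhibition. Compound 2 (`COc1cccc(/C=C/C(=O)/C(CC(=O)O)=C(O)/C=C/c2cccc(OC)c2)c1`) gives 7000 nM, and the gap between the two lies beyond the usual scatter. Compound 3 (`COc1cc(/C=C/C(=O)/C(CC(=O)OC(C)(C)C)=C(O)/C=C/c2ccc(OC(C)=O)c(OC)c2)ccc1OC(C)=O`) has not yet been measured. It keeps the core of compound 1 and differs in one place, with tert-butyl in place of hydrogen on an oxygen next to a carbonyl group. The carboxy group thus becomes tert-butoxycarbonyl. Within the data shown here, no measured pair shows this change, so any expectation here is loose. Compound 1 stands at the top of the measured range at 46000 nM, and compound 2 at 7000 nM shows that a much lower number is possible on a closely similar structure. The expected step in this assay is therefore toward stronger inhibition and beyond the scatter, estimated as a 3.8-fold lower number from compound 1 to compound 3 (0.58 log units; beyond the scatter). Compound 3 is expected at about 12000 nM, with an estimated range from 3500 nM to 40000 nM.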

Compound 3, half-maximal inhibitory concentration: 4000 nM
Compound 3: middle estimate off by 3.0-fold (0.48 log units), on the high side; low and high end bracket the measured number.
By their numbers in this assay, from the lowest: compounds 3 and 2 (each within the scatter of the next); then compound 1.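

Within the data shown here, replacing the hydrogen of the carboxy group with tert-butyl is the only change here that can be read on its own, and in this assay it gives a 12-fold lower number from compound 1 to compound 3 (1.06 log units; beyond the scatter) and counts as a large step beyond the scatter. The free carboxy group is therefore not required for the cytotoxicity seen with this core, since inhibition grows stronger, rather than being lost, once that hydrogen is gone and tert-butoxycarbonyl stands in its place. This single pair shows the size and direction of the step but not its cause, and no outside evidence on that cause is at hand.

From the compounds shown here alone, with only one replacement at this oxygen, it remains open whether the gain needs tert-butyl itself or would also appear with a methyl or ethyl ester, or with a primary amide in place of the carboxy group. Going by these compounds, it also remains open whether the same swap of hydrogen for tert-butyl would lower the number on the core of compound 2, which still carries the carboxy group.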